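This account rests on a few compounds, and the source may have more. Where it says the series, first, only, none or still open, it means among the compounds named here.

Compound 1 `Cc1cc(Oc2ccccc2OCCn2ccc(=O)[nH]c2=O)c(C)c2cc(C#N)ccc12` gives > 100000 nM in a toxicity assay on MT2 cells (Homo sapiens) for cytotoxicity, read by MTT assay (a lower number here means that less compound is tolerated, a higher number that more compound is tolerated), a limit of the assay. Compound 2 `CCc1cc(Oc2ccccc2OCCn2ccc(=O)[nH]c2=O)c(C)c2cc(C#N)ccc12` gives 12000 nM in this assay. Compound 3 `COc1cc(Oc2ccccc2OCCn2ccc(=O)[nH]c2=O)c(C)c2cc(C#N)ccc12` gives > 100000 nM in this assay, again a limit.

The change methyl in place of hydrogen on a saturated chain carbon bound to an aromatic carbon made an at least 8.3-fold lower number from compound 1 to compound 2 (0.92 log units; beyond the scatter); the step reads only as a lower bound because of the limit of > 100000 nM in this assay, at which 2 of the 3 values shown sit. The two cores differ by methoxy in place of methyl on an aromatic carbon. Compound 4 `CCOc1cc(Oc2ccccc2OCCn2ccc(=O)[nH]c2=O)c(C)c2cc(C#N)ccc12` carries the change (methyl in place of hydrogen on a saturated chain carbon bound to an oxygen on an aromatic ring), the same kind of change as that from compound 1 to compound 2, though here the place is a saturated chain carbon bound to an oxygen on an aromatic ring rather than one bound to an aromatic carbon. Resting on that earlier step and on compound 3 sitting at the limit, compound 4 is expected to show an at least 4.0-fold lower number from compound 3 to compound 4 (0.60 log units; beyond the scatter). The estimate for compound 4 is 25000 nM, between 8000 nM and 100000 nM.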

Compound 4, half-maximal cytotoxic concentration: > 100000 nM
Compound 4 ended at the assay's limit; the forecaster's own chance of this, stated with the estimate: 40%; middle value at least 4.0-fold (0.60 log units) away from the limit.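

In this assay compound 4 gives > 100000 nM, a limit of the assay. Among the compounds shown here, the steps from compound 3 and from compound 1 to compound 4 cannot be read, so the data neither confirm nor rule out that methyl in place of hydrogen lowers the number on the core of compound 3 as it did on the core of compound 1, because both ends of those steps stand at the same limit: the limit of > 100000 nM in this assay, at which 3 of the 4 values shown sit. The one readable step, ethoxy in place of ethyl, is an at least 8.3-fold higher number from compound 2 to compound 4 (0.92 log units; beyond the scatter), but that is a different change from the one being carried across.

The compounds shown leave open how compound 3 and compound 4 truly compare. They also leave open whether a longer chain such as propoxy, or an amine in place of the ethoxy, would give a value that can be read.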